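The source may report more compounds than this note shows. Statements on the series, on what has been measured and on what is new or still open speak of the compounds shown alone.

Measured so far:
compound 1 `N[C@H]1CCC[C@@H](N(CC2CC2)C(=O)c2ccccc2OCc2ccccc2)C1`: in an assay on HEK293 cells for inhibition of transient receptor potential cation channel subfamily M member 8 (Homo sapiens), read by FLIPR and calcium flux (on this read-out lower numbers stand for stronger inhibition and higher numbers for weaker inhibition), compound 1 gives 665 nM.
compound 2 `CCN(C(=O)c1ccccc1OCC(C)C)[C@@H]1CCC[C@H](N)C1`: compound 2 returns only a limit, > 2000 nM.

Compound 2 thus stands at the limit of > 2000 nM in this assay, at which 1 of the 2 values shown sits, so no number, only a limit, is known for it. Compound 3 `CCN(C(=O)c1ccccc1-c1ccccc1)[C@@H]1CCC[C@H](N)C1` differs from compound 2 by phenyl in place of isobutoxy on an aromatic carbon. For the measured compounds named here, no step between measured compounds is available to size this change. Starting from a limit, compound 3 is expected to show no step beyond the scatter, an at least 1.3-fold lower number from compound 2 to compound 3 (0.12 log units; that floor lies within the scatter). Compound 3 is therefore estimated in this assay at 1500 nM, in the range 400 nM to 6000 nM, with a real chance that again only a limit is reported.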

Compound 3, antagonist equilibrium constant: > 2000 nM
Compound 3: only a limit was reported; the forecaster's own chance of this, stated with the estimate: 55%; middle value at least 1.3-fold (0.12 log units) from the limit.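

Compound 2 and compound 3 both return only a limit, so no step can be read between them: the limit of > 2000 nM in this assay, at which 2 of the 3 values shown sit.

As far as these compounds go, whether phenyl in place of isobutoxy on an aromatic carbon changes the read-out in this assay, and in which direction, remains open.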